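This account rests on a few compounds, and the source may have more. Where it says the series, first, only, none or still open, it means among the compounds named here.

In a functional assay on Caco-2 cells (Homo sapiens) for inhibition, read by MTT assay, with a stated time of 48 h, tested at 10 uM (on this read-out higher numbers stand for more inhibition of growth at the one concentration tested and lower numbers for less inhibition of growth), compound 3 `CN1CC[C@H](c2c(O)cc(O)c3c(=O)cc(/C=C/c4ccccc4F)oc23)[C@H](O)C1` gives 68%, which lies within the scatter of compound 1 `CN1CC[C@H](c2c(O)cc(O)c3c(=O)cc(/C=C/c4ccc(Cl)cc4)oc23)[C@H](O)C1` at 70%. Compound 2 `CN1CC[C@H](c2c(O)cc(O)c3c(=O)cc(/C=C/c4cccc(Cl)c4)oc23)[C@H](O)C1` gives 55%, and the measured change is a number 13 percentage points higher from compound 2 to compound 3 (beyond the scatter). Compound 4 `CN1CC[C@H](c2c(O)cc(O)c3c(=O)cc(/C=C/c4ccccc4Cl)oc23)[C@H](O)C1` has chloro in place of fluoro on an aromatic carbon, ortho to a large group: chloro in place of fluoro on an aromatic carbon. Within the data shown here, no measured step makes this exact swap. The closest is a number 2 percentage points lower from compound 1 to compound 3 (within the scatter), where 2-fluorophenyl replaces 4-chlorophenyl. A larger change is a number 15 percentage points lower from compound 1 to compound 2 (beyond the scatter), where 3-chlorophenyl replaces 4-chlorophenyl, so some uncertainty remains. In this assay no step beyond the scatter is therefore expected. The expected step is a number 2 percentage points lower from compound 3 to compound 4 (within the scatter). For compound 4 the estimated value is 66%, with an expected range from 54% to 76%.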

Compound 4, percent growth inhibition at one concentration: 65%
Compound 4: middle estimate off by 1 percentage points, on the high side, and the stated range covers the measured number.
By their numbers in this assay, from the lowest: compounds 2, 4, 3 and 1 (each within the scatter of the next, the first and the last beyond it).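

In this assay the direct swap of chloro for fluoro on this aromatic carbon, ortho to a large group, gives a number 3 percentage points lower from compound 3 to compound 4 (within the scatter) and so does not separate the two halogens. Moving the chloro gives a number 10 percentage points higher from compound 2 to compound 4 (within the scatter) and a number 5 percentage points lower from compound 1 to compound 4 (within the scatter) so the 2-chlorophenyl compound lies within the scatter of both other chlorophenyl compounds, even though those two differ by a number 15 percentage points lower from compound 1 to compound 2 (beyond the scatter) beyond it. No measurement here gives a reason for these results. From the compounds shown here alone, whether a larger group such as bromo or methoxy at this place would hold the number stays open. So does the effect of an amine there.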